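Cytotoxicity of a stilbene series: from carboxylate to diamine

The source may report more compounds than this note shows. Statements on the series, on what has been measured and on what is new or still open speak of the compounds shown alone.

Measured so far in an ADME assay on NCM460 cells (Homo sapiens) for cytotoxicity, read by CCK-8 assay, with a stated time of 48 h; a lower number here means a stronger inhibitor, a higher number a weaker inhibitor:
- Compound 1 `COc1ccc(/C=C\c2cc(OC)c(OC)c(OC)c2)cc1OCc1ccc(CN2CC[C@H](C(=O)O)C2)cc1` gives > 50000 nM, which is a limit of the assay rather than a number.
- Compound 2 `COc1ccc(/C=C\c2cc(OC)c(OC)c(OC)c2)cc1OCc1ccc(CN2CCCCC2C(=O)O)cc1` gives > 50000 nM, again a limit of the assay.
- Compound 3 `COc1ccc(/C=C\c2cc(OC)c(OC)c(OC)c2)cc1OCc1ccc(CNCCNC(C)=O)cc1` gives 54000 nM.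

Compound 2 therefore stands at a limit, as does one of the two other values shown, so no ordering among the three compounds can be read. For the measured compounds named here, the steps a step that the two limits leave unreadable from compound 1 to compound 2, a step that the limit leaves unreadable from compound 2 to compound 3 and a step that the limit leaves unreadable from compound 1 to compound 3 are all left unreadable by the limits, and the limit of > 50000 nM in this assay, at which 2 of the 3 values shown sit, is the only firm piece of information on the measured steps.

The new compound 4 `COc1ccc(/C=C\c2cc(OC)c(OC)c(OC)c2)cc1OCc1ccc(CNCCN(C)C)cc1` differs from compound 2 as follows: (2-(dimethylamino)ethyl)amino in place of 2-carboxypiperidin-1-yl on a saturated chain carbon bound to an aromatic carbon. Since all measured values cluster at or near the same limit, no step beyond the scatter is expected from this change in this assay. Compound 4 is therefore expected to give about 50000 nM, between 20000 nM and 120000 nM. The expected step is a number no higher from compound 2 to compound 4 (the limit leaves the size open), most likely reported again only as a limit.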

Compound 4, half-maximal inhibitory concentration: 35000 nM
Compound 4: the middle estimate sits 1.4-fold (0.15 log units) above what was measured; low and high end bracket the measured number.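

In this assay, for the compounds shown here, (2-(dimethylamino)ethyl)amino in place of 2-carboxypiperidin-1-yl gives an at least 1.4-fold lower number from compound 2 to compound 4 (0.15 log units; that floor lies within the scatter), and the same group in place of 3-carboxypyrrolidin-1-yl gives an at least 1.4-fold lower number from compound 1 to compound 4 (0.15 log units; that floor lies within the scatter), so neither change can yet be told apart from scatter, although these floors are the first sizes that can be put on a step from the acids at this position. Dimethylamino in place of acetamido, on a saturated chain carbon two bonds along the chain from an amine nitrogen, gives a 1.5-fold lower number from compound 3 to compound 4 (0.19 log units; within the scatter), so compound 3 and compound 4 cannot be separated in this assay. The true size of the steps from the two acids stays unknown, as compound 1 and compound 2 remain limits rather than numbers: the limit of > 50000 nM in this assay, at which 2 of the 4 values shown sit.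

From the compounds shown here alone, whether a longer chain between the two nitrogens would give a step beyond the scatter remains open. So does the effect of a morpholine in place of the dimethylamino group.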